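This account rests on a few compounds, and the source may have more. Where it says the series, first, only, none or still open, it means among the compounds named here.

Three compounds of the series have numbers in a functional assay on the whole organism for inhibition, with Gossypium hirsutum as the target; on this read-out lower numbers stand for stronger inhibition and higher numbers for weaker inhibition. Compound 1 `CC(Cl)/C=C/C(=O)N(Cc1ccc(C#N)cc1)CC(C)C` gives 158 nM, compound 2 `CC(Br)/C=C/C(=O)N(Cc1ccc(Cl)cc1)CC(C)C` gives 79.4 nM, and compound 3 `CC(Cl)/C=C/C(=O)N(Cc1ccc(C(F)(F)F)cc1)CC(C)C` gives 1000 nM. Compound 3 therefore has the highest number of the three and is the weakest inhibitor so far, with both of the others beyond the scatter from it.

Compound 4 `CC(Cl)/C=C/C(=O)N(Cc1ccc(Cl)cc1)CC(C)C` is compound 3 with chloro in place of trifluoromethyl on an aromatic carbon.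

Among the measured compounds shown here, only one measured step concerns this place. Trifluoromethyl in place of cyano gave a 6.3-fold higher number from compound 1 to compound 3 (0.80 log units; beyond the scatter), a modest change beyond the scatter, so this assay does respond to the group at this carbon. Compound 2 already carries the chloro group and gives 79.4 nM, but it has bromo rather than chloro on the chain. For the measured compounds named here, no measured step isolates that second difference, so compound 2 is a guide and not a direct match.

A modest step towards a lower number is therefore expected, with compound 4 landing near compound 1 and compound 2 rather than near compound 3. The estimated change is a 6.3-fold lower number from compound 3 to compound 4 (0.80 log units; beyond the scatter). For compound 4 the expected value is 160 nM, with an estimated range of 50 nM to 500 nM.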

Compound 4, half-maximal inhibitory concentration: 251 nM
For compound 4 the middle estimate is 1.6-fold (0.20 log units) below the measured one; measured number inside the range.
By their numbers in this assay, from the lowest: compounds 2, 1 and 4 (each within the scatter of the next, the first and the last beyond it); then compound 3.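

In this assay, the aromatic carbon now has three groups to compare: chloro in place of trifluoromethyl gives a 4.0-fold lower number from compound 3 to compound 4 (0.60 log units; beyond the scatter), while chloro in place of cyano gives a 1.6-fold higher number from compound 1 to compound 4 (0.20 log units; within the scatter). Among these three groups, trifluoromethyl alone stands apart at this carbon, and chloro and cyano cannot be separated. The halogen on the chain also matters, which no earlier step could isolate: with the aromatic chloro held constant, chloro in place of bromo gives a 3.2-fold higher number from compound 2 to compound 4 (0.50 log units; beyond the scatter), so this series responds at two separate places, and no measurement on hand accounts for either response.

Compound 2 is the only bromo compound shown, so it remains open whether bromo on the chain would lower the number to a similar extent alongside cyano or trifluoromethyl on the aromatic carbon. Also open, from the compounds shown here alone, is how the series would respond to an amine or a carboxylic acid at the aromatic carbon, to fluoro on the chain, or to a longer chain on the amide nitrogen.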